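A few compounds are considered here, and "the series" means these few. Any claim that something is new, unique, unknown or untested is made for them only; others in the source may bear on it.

Working notes on the series. In an ADME assay on MDCK-II cells (Canis lupus familiaris) for permeability (on this read-out higher numbers stand for higher permeability and lower numbers for lower permeability), compound 2 `CCCC(Oc1ccc(-n2cc(C(F)(F)F)cn2)cc1)c1ccc(C(=O)NCCC(=O)O)cc1` gives 3.1 10^-6 cm/s. Compound 1 `CCCC(Nc1cc(C)c(-n2cc(C(F)(F)F)cn2)c(C)c1)c1ccc(C(=O)NCCC(=O)O)cc1` gives 2.7 10^-6 cm/s in this assay, and the two numbers lie within the scatter of each other, so nothing separates them on this read-out; compound 2 simply has the numerically larger of the two values, a distinction without substance. No change between two measured compounds is available from which a step could be read.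

Compound 3 `CCCC(Oc1ccc(-n2cc3ccccc3n2)cc1)c1ccc(C(=O)NCCC(=O)O)cc1` is not yet measured. Its relation to compound 2 is 2H-indazol-2-yl in place of 4-(trifluoromethyl)-1H-pyrazol-1-yl on an aromatic carbon. Both groups are of equal heavy-atom count with the same count of donors and acceptors and no charge, and the acid and amide side of the molecule is untouched. Within the data shown here, with no measured step to lean on, the expectation is a change in this assay of no clear direction and not beyond the scatter; the step of a 1.1-fold higher number from compound 2 to compound 3 (0.05 log units; within the scatter) that this estimate implies is expected to stay within it. Compound 3 is estimated at 3.5 10^-6 cm/s, with a range from 1.5 10^-6 cm/s to 8 10^-6 cm/s.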

Compound 3, apparent permeability: 2.2 10^-6 cm/s
Compound 3: middle estimate off by 1.6-fold (0.20 log units), on the high side; the measured number falls inside the stated range.
By their numbers in this assay, from the lowest: compounds 3, 1 and 2 (each within the scatter of the next).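

At this position, on an aromatic carbon para to a large group, 2H-indazol-2-yl in place of 4-(trifluoromethyl)-1H-pyrazol-1-yl gives a 1.4-fold lower number from compound 2 to compound 3 (0.15 log units; within the scatter) in this assay. This first readable step in the series shows that the two groups are not separated on this read-out, although the entering group carries a six-membered aromatic ring of carbon only and no fluorine. No measurement at hand bears on why the two groups read alike.

The compounds shown leave open whether an amine or a nitrile on this aromatic carbon, or an ester in place of the carboxylic acid, would give a step beyond the scatter. Compound 1 and compound 2 differ in more than one place, so no single change can be read from that pair.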